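The source may report more compounds than this note shows. Statements on the series, on what has been measured and on what is new or still open speak of the compounds shown alone.

In a functional assay on MCF7 cells (Homo sapiens) for antiproliferative activity, read by MTT assay, with a stated time of 48 h (on this read-out higher numbers stand for weaker inhibition and lower numbers for stronger inhibition), compound 1, with the structure `CCc1ccccc1-n1nncc1CN1C(=O)C2(C(C#N)=C(N)Oc3c(N)cc4nc5ccccc5nc4c32)c2ccccc21`, gives 24600 nM. Compound 2, with the structure `COc1ccc(OC)c(-n2nncc2CN2C(=O)C3(C(C#N)=C(N)Oc4c(N)cc5nc6ccccc6nc5c43)c3ccccc32)c1`, keeps the same core and differs only in the group attached to the aromatic nitrogen of the three-nitrogen ring. In this assay, going by the values given here, compound 2 gives 28100 nM, which is the higher of the two numbers measured so far; the step of a 1.1-fold higher number from compound 1 to compound 2 (0.06 log units; within the scatter) shows that the two compounds cannot be told apart on this read-out.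

Compound 3, with the structure `N#CC1=C(N)Oc2c(N)cc3nc4ccccc4nc3c2C12C(=O)N(Cc1cnnn1-c1ccc(Cl)cc1[N+](=O)[O-])c1ccccc12`, is not yet measured. Among the compounds with values here, it differs from compound 2 in the same position as the one measured step: 4-chloro-2-nitrophenyl in place of 2,5-dimethoxyphenyl on an aromatic nitrogen. Within the data shown here, the only step that bears on this change, a 1.1-fold higher number from compound 1 to compound 2 (0.06 log units; within the scatter), swapped one aryl group for another at this aromatic nitrogen and produced nothing beyond the scatter. With no other evidence, the step of a 1.0-fold lower number from compound 2 to compound 3 (0.02 log units; within the scatter) is expected to stay within the scatter as well. Compound 3 is therefore estimated to give about 27000 nM in this assay, with a likely range from 12000 nM to 60000 nM.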

Compound 3, half-maximal inhibitory concentration: > 50000 nM
Compound 3 was reported as a limit (the forecaster's own chance of this, stated with the estimate: 10%); middle value at least 1.8-fold (0.26 log units) away from the limit.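

In this assay compound 3 is reported only as a limit of the assay, not as a number: the limit of > 50000 nM in this assay, at which 1 of the 3 values shown sits.

Putting 4-chloro-2-nitrophenyl in place of 2,5-dimethoxyphenyl gives an at least 1.7-fold higher number from compound 2 to compound 3 (0.25 log units; that floor lies within the scatter), and putting it in place of 2-ethylphenyl gives an at least 2.0-fold higher number from compound 1 to compound 3 (0.30 log units; that floor lies within the scatter). The earlier swap at this aromatic nitrogen, a 1.1-fold higher number from compound 1 to compound 2 (0.06 log units; within the scatter), gave a step with a known size that stayed within the scatter, whereas these two new steps have only a floor and no upper end. The result therefore shows that this position may respond more strongly to a change of aryl group than the first pair suggested, but the true size of the steps could still be small or much larger.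

The compounds shown leave open whether the chlorine or the nitro group matters more, which a phenyl ring carrying only one of the two could separate. They also leave open what a plain phenyl ring, an amine-bearing phenyl ring or a simple alkyl chain would give on this aromatic nitrogen.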